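Aryl to benzyl on the amine nitrogen of a shared core

The compounds below may be only part of what the source reports. "The series", "measured", "known", "first", "only" and "open" are said of these compounds alone.

Measured so far:
- compound 1 `O=C(C1=C(Nc2ccc(OC(F)(F)F)cc2)C(=O)N(CCCn2ccnc2)C1c1ccc(Br)cc1)c1ccccc1`: 17900 nM
- compound 2 `O=C(C1=C(Nc2ccccc2Br)C(=O)N(CCCn2ccnc2)C1c1ccc(Br)cc1)c1ccccc1`: 19600 nM

Both compounds were tested in a functional assay on SAOS-2 cells (Homo sapiens) for antiproliferative activity, read by MTT assay, with a stated time of 72 h; on this read-out lower numbers stand for stronger inhibition and higher numbers for weaker inhibition. In this assay compound 1 gives 17900 nM and compound 2 gives 19600 nM. Among the measured compounds shown here, the only measured step is a 1.1-fold higher number from compound 1 to compound 2 (0.04 log units; within the scatter), so compound 2 cannot be set apart from compound 1: the two numbers are indistinguishable, and both stand in the weak range.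

Compound 3 `O=C(C1=C(NCc2ccccc2)C(=O)N(CCCn2ccnc2)C1c1ccc(Br)cc1)c1ccccc1` is not yet measured. It differs from compound 2 in one place: benzyl in place of 2-bromophenyl on an amine nitrogen. The measured step exchanges one aromatic ring for another directly on the amine nitrogen, and it was within the scatter. For the measured compounds named here, the change to compound 3 is of a different kind, since the ring now hangs one carbon further out, so that step bears on it only loosely; no measured pair tells what such a move does here.

With nothing pointing either way, the expected result for compound 3 is a number close to that of compound 2, a step of a 1.0-fold higher number from compound 2 to compound 3 (0.01 log units; within the scatter), giving an estimate of 20000 nM with a range from 7000 nM to 55000 nM.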

Compound 3, half-maximal inhibitory concentration: 31600 nM
Compound 3: middle estimate off by 1.6-fold (0.20 log units), on the low side, within the range that was stated.
By their numbers in this assay, from the lowest: compounds 1, 2 and 3 (each within the scatter of the next).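

Up to now only rings set directly on the amine nitrogen had been compared. In this assay, benzyl on that nitrogen gives a 1.6-fold higher number from compound 2 to compound 3 (0.21 log units; within the scatter) and also a 1.8-fold higher number from compound 1 to compound 3 (0.25 log units; within the scatter), so this position has now tolerated a ring held away from the nitrogen as well as the two substituted phenyl rings, with no difference that can be told from the scatter. No measurement on hand explains why these three groups cannot be told apart, and none links the numbers to any property of the groups.

This change also removes the bromine while it moves the ring, so the step from compound 2 to compound 3 cannot separate the two edits, and a plain phenyl on the nitrogen would be the group that splits them. Also open, going by these compounds, is whether a longer chain such as 2-phenylethyl, a group with no ring such as butyl, or a benzyl carrying a bromine would shift the number beyond the scatter at this nitrogen.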